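A few compounds are considered here, and "the series" means these few. Any claim that something is new, unique, unknown or untested is made for them only; others in the source may bear on it.

Values so far in a functional assay on SW-620 cells (Homo sapiens); on this read-out lower numbers stand for stronger inhibition of growth and higher numbers for weaker inhibition of growth
- compound 1 `O=S(=O)(/C=C/c1ccc(Cl)cc1)Cc1ccc(Nc2ncnc3ccccc23)cc1` gives 77000 nM 
- compound 2 `O=S(=O)(/C=C/c1ccc(F)cc1Cl)Cc1ccc(Nc2ncnc3ccccc23)cc1` gives 100000 nM 
- compound 3 `O=S(=O)(/C=C/c1ccc(Cl)cc1)Cc1ccc(Nc2ncnc3ccc(Br)cc23)cc1` gives 45000 nM 

The number for compound 3 cannot be separated from that of compound 1 within the scatter, and it lies beyond the scatter under that of compound 2.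

Compound 4 `O=S(=O)(/C=C/c1ccc(F)cc1F)Cc1ccc(Nc2ncnc3ccc(Br)cc23)cc1` has not yet been measured. It carries 2,4-difluorophenyl in place of 4-chlorophenyl on a double-bonded chain carbon bound to a double-bonded chain carbon.

Among the measured compounds shown here, the one measured change at this place, a 1.3-fold higher number from compound 1 to compound 2 (0.11 log units; within the scatter), stayed within the scatter. The bromo change, a 1.7-fold lower number from compound 1 to compound 3 (0.23 log units; within the scatter), is shared by compound 3 and compound 4, so it does not bear on this step.

No step beyond the scatter is therefore expected in this assay. The expected change is small, a 1.2-fold higher number from compound 3 to compound 4 (0.09 log units; within the scatter), and would lie within the scatter. For compound 4 the estimated value is 55000 nM, with an expected range from 25000 nM to 110000 nM.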

Compound 4, concentration for 50% growth inhibition: 100000 nM
Estimate against measurement, compound 4: 1.8-fold (0.26 log units) below; measured number inside the range.
By their numbers in this assay, from the lowest: compounds 3, 1, 2 and 4 (each within the scatter of the next, the first and the last beyond it).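

In this assay, among the compounds shown here, the change from 4-chlorophenyl to 2,4-difluorophenyl gives a 2.2-fold higher number from compound 3 to compound 4 (0.35 log units; beyond the scatter), the first step at this place to pass beyond the scatter, whereas a 1.3-fold higher number from compound 1 to compound 2 (0.11 log units; within the scatter) stayed within it. The group at this place can therefore shift the number, at least in a compound carrying the bromo group. Nothing available explains this step.

The compounds shown leave open whether 2,4-difluorophenyl would act alike without the bromo group. They also leave open how a phenyl bearing an amine or a carboxylic acid would compare.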